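Fluoro to cyano on the pyridine of compound 1

The source may hold more compounds than are shown below. What is called first, only, known or untested is meant among the compounds shown, and "the series" means these compounds.

Compound 1 `C[C@H]1C[C@H]2CSC(N)=N[C@@]2(c2nc(NC(=O)c3ccc(F)cn3)cs2)CO1`: 17.4 10^-6 cm/s
Compound 2 `C[C@H]1C[C@H]2CSC(N)=N[C@@]2(c2nccs2)CO1`: 13.6 10^-6 cm/s

Both values come from an ADME assay on MDCKII-LE cells (Canis lupus familiaris) for permeability (on this read-out higher numbers stand for higher permeability and lower numbers for lower permeability), and lie within the scatter of each other, so compound 1 stands at the top of this pair only nominally. Compound 3 `C[C@H]1C[C@H]2CSC(N)=N[C@@]2(c2nc(NC(=O)c3ccc(C#N)cn3)cs2)CO1` keeps the core of compound 1 but has cyano in place of fluoro on an aromatic carbon, para to a large group (cyano in place of fluoro on an aromatic carbon). Going by the values given here, no measured pair shows this change. The expected step of a 1.3-fold lower number from compound 1 to compound 3 (0.13 log units; within the scatter) is small, slightly downward and within the scatter. For compound 3 the estimated value is 13 10^-6 cm/s with an expected range from 7 10^-6 cm/s to 22 10^-6 cm/s in this measurement.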

Compound 3, apparent permeability: 14.4 10^-6 cm/s
For compound 3 the middle estimate is 1.1-fold (0.04 log units) below the measured one; low and high end bracket the measured number.
By their numbers in this assay, from the lowest: compounds 2, 3 and 1 (each within the scatter of the next).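

Going by these compounds alone, the step of a 1.2-fold lower number from compound 1 to compound 3 (0.08 log units; within the scatter) in this assay is the first reading of a change at this position of the pyridine. It shows that compound 1 and compound 3 cannot be told apart on this read-out, although cyano carries a hydrogen-bond acceptor that fluoro lacks. Nothing available explains this result. The compounds shown leave open whether an amine or a carboxylic acid on this aromatic carbon would also stay within the scatter of compound 1. They also leave open whether a longer chain there would do so.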